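Replacing 2-methoxyphenyl with 4-hydroxyphenyl in compound 2

The source may report more compounds than this note shows. Statements on the series, on what has been measured and on what is new or still open speak of the compounds shown alone.

Among the compounds with values here, in a functional assay on DU-145 cells (Homo sapiens) for inhibition, read by trypan blue exclusion, with a stated time of 96 h (a higher number here means a weaker inhibitor of growth, a lower number a stronger inhibitor of growth), compound 2 `COc1ccccc1/C=C(/SCc1ccc(Cl)cc1)C(=O)c1ccc(Cl)cc1` gives 1000 nM as the lowest of the three numbers so far. Compound 1 `Cc1ccc(CS/C(=C/c2ccc(O)cc2)C(=O)c2ccc(Cl)cc2)cc1` stands at 10000 nM and compound 3 `COc1ccccc1/C=C(/SCc1ccc(C)cc1)C(=O)c1ccc(Cl)cc1` stands at 10000 nM so both sit well above it.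

Compound 4 `O=C(/C(=C\c1ccc(O)cc1)SCc1ccc(Cl)cc1)c1ccc(Cl)cc1` has not yet been measured. It carries 4-hydroxyphenyl in place of 2-methoxyphenyl on a double-bonded chain carbon bound to a double-bonded chain carbon.

The closest evidence is the same swap running the opposite way between two compounds that carry methyl instead of chloro (no change at the digits printed from compound 1 to compound 3 (within the scatter)). Within the data shown here, no measured pair shows this swap with chloro present, so carrying that result over is an assumption. Compound 4 keeps the chloro group, so the larger step seen on losing it (a 10-fold higher number from compound 2 to compound 3 (1.00 log units; beyond the scatter)) is not expected to apply here.

On that basis, the estimated step is small (no change at the digits printed from compound 2 to compound 4 (within the scatter)), with no shift beyond the scatter expected in this assay in either direction. Compound 4 is expected at 1000 nM with an estimated range from 300 nM up to 5000 nM as the measurement's likely span.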

Compound 4, concentration for 50% growth inhibition: 10000 nM
Estimate against measurement, compound 4: 10-fold (1.00 log units) below, and the stated range ends below it.
By their numbers in this assay, from the lowest: compound 2; then compounds 1, 3 and 4 (each within the scatter of the next).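

In this assay, the change from 2-methoxyphenyl to 4-hydroxyphenyl now has a visible effect when chloro is present (a 10-fold higher number from compound 2 to compound 4 (1.00 log units; beyond the scatter)), so the flat result seen earlier with methyl does not hold across both cores: (the same change on two cores in this assay, no change at the digits printed (within the scatter) from compound 1 to compound 3 and a 10-fold lower number (1.00 log units; beyond the scatter) from compound 4 to compound 2, 10-fold (1.00 log units) apart, beyond the scatter of two such steps). The chloro group likewise proves not to matter on every core, as with 4-hydroxyphenyl in place, the change from methyl to chloro does nothing measurable (no change at the digits printed from compound 1 to compound 4 (within the scatter)), unlike the same pair of groups with 2-methoxyphenyl in place: (the same change on two cores in this assay, a 10-fold higher number (1.00 log units; beyond the scatter) from compound 2 to compound 3 and no change at the digits printed (within the scatter) from compound 4 to compound 1, 10-fold (1.00 log units) apart, beyond the scatter of two such steps). Among these four compounds, then, neither change has a fixed effect of its own, and the lower number appears only in compound 2, where 2-methoxyphenyl and chloro occur together.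

The compounds shown leave open whether the lower number of compound 2 follows the methoxy group itself or the place it holds on the ring, a question that 4-methoxyphenyl and 2-hydroxyphenyl versions of compound 2 would separate. Going by these compounds, it is also open whether fluoro or bromo could stand in for chloro alongside 2-methoxyphenyl.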